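The source may report more compounds than this note shows. Statements on the series, on what has been measured and on what is new or still open speak of the compounds shown alone.

Working notes on the series, read in an ADME assay on cells (Erythrocyte, Homo sapiens), read by spectrophotometry and hemolysis, with a stated time of 24 h; on this read-out lower numbers stand for stronger inhibition and higher numbers for weaker inhibition. Compound 1 `CC(=O)c1ccccc1OCc1ccc2no[n+]([O-])c2c1` gives > 200 uM, which is a limit of the assay and not a number. Compound 2 `N=C(N)N/N=C\c1ccccc1OCc1ccc2no[n+]([O-])c2c1` gives 58 uM. Compound 3 `NC(=S)N/N=C\c1ccccc1OCc1ccc2no[n+]([O-])c2c1` gives 189 uM, the higher of the two actual numbers, with compound 2 as its nearest neighbour. The steps out of the limit compound are an at least 3.4-fold lower number from compound 1 to compound 2 (0.53 log units; beyond the scatter) and an at least 1.0-fold lower number from compound 1 to compound 3 (0.02 log units; that floor lies within the scatter); both are bounded by the limit of > 200 uM in this assay, at which 1 of the 3 values shown sits.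

Compound 4 `NC(=O)N/N=C\c1ccccc1OCc1ccc2no[n+]([O-])c2c1` has not yet been measured in this assay. Its difference from compound 3 is a group of 3 heavy atoms (1 carbon, 1 nitrogen, 1 oxygen; no ring) in place of a group of 3 heavy atoms (1 carbon, 1 nitrogen, 1 sulfur; no ring), on an amine nitrogen: a carbamoyl enters on an amine nitrogen whose other neighbours are: double-bonded nitrogen. Within the data shown here, the closest precedent is a 3.3-fold higher number from compound 2 to compound 3 (0.51 log units; beyond the scatter), which changed a group of the same heavy-atom count at the same place and stayed modest. Among the measured compounds shown here, no measured step makes this exact exchange of sulfur for oxygen, so its direction is not set by the data. Since compound 3 at 189 uM already holds the higher of the two actual numbers, no step beyond the scatter is expected. The expected step is a 1.0-fold higher number from compound 3 to compound 4 (0.00 log units; within the scatter). For compound 4 the estimated value is 190 uM, with an expected range from 90 uM to 380 uM.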

Compound 4, concentration for 50% inhibition: > 100 uM
Compound 4 gave a limit, no number; the forecaster's own chance of this, stated with the estimate: 40%; the middle value lies beyond the limit too.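

With the carbamoyl on the amine nitrogen, compound 4 yields a limit and not a number: the limit of > 100 uM in this assay, at which 1 of the 4 values shown sits. Set against the group carried by compound 2, the change gives an at least 1.7-fold higher number from compound 2 to compound 4 (0.23 log units; that floor lies within the scatter), so at this floor the carbamoyl is not separated from that group, whereas the exchange in a 3.3-fold higher number from compound 2 to compound 3 (0.51 log units; beyond the scatter) is separated from it. The steps from compound 3 and from compound 1 to compound 4 cannot be read, which leaves the exchange of sulfur for oxygen at this place without a size or a direction in this assay.

Open, going by these compounds, is whether compound 4 lies on either side of compound 3 at 189 uM, so the series does not yet tell whether the thiocarbonyl and carbonyl forms differ at all in this read-out. Among these compounds, also open is how a plain amine or a carboxylic acid in place of the carbamoyl would read, and whether any group other than the one in compound 2 at 58 uM gives a number clearly lower than that of compound 3.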